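A few compounds are considered here, and "the series" means these few. Any claim that something is new, unique, unknown or untested is made for them only; others in the source may bear on it.

In a functional assay on SK-BR-3 cells (Homo sapiens) for antiproliferative activity (a lower number here means a stronger inhibitor, a higher number a weaker inhibitor), the measured compounds are:
- compound 1 `CC(C)=CCc1cc(C(=O)Nc2cc3ccc(OCCC4CCCCN4)c(C)c3oc2=O)ccc1O`: 640 nM
- compound 2 `CC(C)=CCc1cc(C(=O)Nc2cc3ccc(OCC4CCCNC4)c(C)c3oc2=O)ccc1O`: 600 nM
- compound 3 `CC(C)=CCc1cc(C(=O)Nc2cc3ccc(OCC4CCN(C)C4)c(C)c3oc2=O)ccc1O`: 920 nM

Compound 3, at 920 nM, stands within the scatter of both other compounds, as a 1.4-fold higher number from compound 1 to compound 3 (0.16 log units; within the scatter) and a 1.5-fold higher number from compound 2 to compound 3 (0.19 log units; within the scatter) show. The next compound, compound 4 `CC(C)=CCc1cc(C(=O)Nc2cc3ccc(OCCCN4CCCCC4)c(C)c3oc2=O)ccc1O`, keeps the shared core and changes only the amine-bearing side group: 2-(piperidin-1-yl)ethyl in place of 1-methylpyrrolidin-3-yl on a saturated chain carbon bound to an oxygen on an aromatic ring. Cut one bond further out, the same difference reads (1-methylpyrrolidin-3-yl)methoxy to 3-(piperidin-1-yl)propoxy.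

All three measured steps change this same side group, so they are the ones that bear on the new change. Besides the two steps to compound 3, there is a 1.1-fold lower number from compound 1 to compound 2 (0.03 log units; within the scatter). None of them leaves the scatter, although the side groups differ in ring size and in how the ring is attached. Within the data shown here, no measured compound carries the 2-(piperidin-1-yl)ethyl group, however, so this evidence is indirect and the range should stay wide. No step beyond the scatter is expected in this assay. The estimated step is a 1.3-fold lower number from compound 3 to compound 4 (0.12 log units; within the scatter). Compound 4 is expected at about 700 nM, with an estimated range of 300 nM to 1600 nM.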

Compound 4, half-maximal inhibitory concentration: > 50000 nM
Compound 4 ended at the assay's limit; the forecaster's own chance of this, stated with the estimate: 3%; at least 71-fold (1.85 log units) between middle value and limit.
By their numbers in this assay, from the lowest: compounds 2, 1 and 3 (each within the scatter of the next). At a limit, above all of these: compound 4.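

In this assay, among these compounds, compound 4 gives > 50000 nM, which is a limit of the assay and not a number, so the steps to it have only a lower bound: the limit of > 50000 nM in this assay, at which 1 of the 4 values shown sits. Even so, the change at this position is large, with an at least 54-fold higher number from compound 3 to compound 4 (1.73 log units; beyond the scatter), an at least 83-fold higher number from compound 2 to compound 4 (1.92 log units; beyond the scatter) and an at least 78-fold higher number from compound 1 to compound 4 (1.89 log units; beyond the scatter), whereas the side groups of the earlier compounds all stayed within the scatter of one another. The position on a saturated chain carbon bound to an oxygen on an aromatic ring therefore does not accept every amine-bearing group alike: compounds 1, 2 and 3 carry their rings through a ring carbon, while compound 4 alone carries a 2-(piperidin-1-yl)ethyl group, joined through the ring nitrogen.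

Compound 4 differs from the others in both chain length and ring attachment, so the compounds shown cannot tell which of the two goes with the loss of activity. On these data alone, a (piperidin-1-yl)methyl group in place of 2-(piperidin-1-yl)ethyl, or a 2-(piperidin-2-yl)ethyl group, would separate the two, and how far the true value of compound 4 lies past the limit stays open.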